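The source may report more compounds than this note shows. Statements on the series, on what has been measured and on what is new or still open speak of the compounds shown alone.

Of the compounds shown here, two built on the shared core have so far been tested in a functional assay on HepG2 cells (Homo sapiens) for cytotoxicity, with a stated time of 72 h; on this read-out lower numbers stand for an effect already at smaller amounts and higher numbers for an effect only at larger amounts of compound. Compound 1 `C=C[C@@](C)(/C=C/c1ccc(O)c(C=O)c1)CCC=C(C)C` gives only a limit of the assay, not a number: > 52000 nM. Compound 2 `C=C[C@@](C)(/C=C/c1ccc(O)c(/C=C/C(=O)c2ccccc2)c1)CCC=C(C)C` also gives only a limit: > 52000 nM. Compound 2 therefore stands at the limit of > 52000 nM in this assay, at which 2 of the 2 values shown sit, so the numbers offer no way to rank it against compound 1.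

The next compound to be measured is compound 3 `C=C[C@@](C)(/C=C/c1ccc(O)c(/C=C/C#N)c1)CCC=C(C)C`. It differs from compound 2 in one place, with cyano in place of benzoyl on a double-bonded chain carbon bound to a double-bonded chain carbon. Among the measured compounds shown here, no measured step between two compounds is available as a guide. For compound 3, no step beyond the scatter is expected in this assay, in either direction, because the limit of compound 2 reads > 52000 nM. In numbers, the expected change is a number no higher from compound 2 to compound 3 (the limit leaves the size open). The estimated value for compound 3 is 52000 nM, with an expected range from 25000 nM to 100000 nM.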

Compound 3, half-maximal effective concentration: > 52000 nM
Compound 3: no number, only a limit (the forecaster's own chance of this, stated with the estimate: 80%); the middle value sits exactly at the limit.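

Among the compounds shown here, compound 1, compound 2 and compound 3 each give only a limit, not a number, in this assay, so no step among them can be read: (the limit of > 52000 nM in this assay, at which 3 of the 3 values shown sit). The compounds shown leave open whether formyl, the benzoyl-bearing chain and the cyano-bearing chain differ at all on this read-out.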